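The compounds below may be only part of what the source reports. "The series", "measured", "known", "first", "only" and "open" are said of these compounds alone.

Series notes. Three measured compounds share the core of compound 1 `O=C(NCCCCc1ccccc1)c1cccc(C2SCC(=O)N2c2ccccc2)c1` and differ only in the group on an amide-type nitrogen in a ring. In a functional assay on SJSA-1 cells (Homo sapiens) for inhibition, read by CCK-8 assay, with a stated time of 72 h, tested at 1 uM (on this read-out higher numbers stand for more inhibition at the one concentration tested (going by the name of the read-out) and lower numbers for less inhibition), compound 1 gives 73%. Compound 2 `Cc1cccc(N2C(=O)CSC2c2cccc(C(=O)NCCCCc3ccccc3)c2)c1` gives 84% in this assay, and compound 3 `COc1cc(F)ccc1N1C(=O)CSC1c1cccc(C(=O)NCCCCc2ccccc2)c1` gives 77%. Compound 3 stands second highest of the three numbers; the nearest number to it is given by a number 4 percentage points higher from compound 1 to compound 3 (within the scatter), and the furthest by a number 7 percentage points lower from compound 2 to compound 3 (within the scatter). For the measured compounds named here, the only step beyond the scatter among the measured compounds is a number 11 percentage points higher from compound 1 to compound 2 (beyond the scatter), a methyl in place of hydrogen on an aromatic carbon.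

Compound 4 `COc1cccc(OC)c1N1C(=O)CSC1c1cccc(C(=O)NCCCCc2ccccc2)c1` is not yet measured. It differs from compound 3 in one place: 2,6-dimethoxyphenyl in place of 4-fluoro-2-methoxyphenyl on an amide-type nitrogen in a ring. Going by the values given here, the steps that bear on this change are the two that also exchange the group on the amide-type nitrogen in a ring, a number 4 percentage points higher from compound 1 to compound 3 (within the scatter) and a number 7 percentage points lower from compound 2 to compound 3 (within the scatter), both within the scatter. Among the compounds with values here, the methyl change, a number 11 percentage points higher from compound 1 to compound 2 (beyond the scatter), is of another kind and is the only step beyond it. The expected outcome in this assay is therefore a step within the scatter, in no firm direction: a number 1 percentage points higher from compound 3 to compound 4 (within the scatter). Compound 4 is expected to give 78% in this assay, with a range from 68% to 88%.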

Compound 4, a percentage reported as inhibition, at one concentration (the size of the read-out at that concentration, not a potency): 72%
For compound 4 the middle estimate is 6 percentage points above the measured one; measured number inside the range.
By their numbers in this assay, from the lowest: compounds 4, 1, 3 and 2 (each within the scatter of the next, the first and the last beyond it).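

Notes on the group on the amide-type nitrogen in a ring: in this assay, 2,6-dimethoxyphenyl in place of 4-fluoro-2-methoxyphenyl gives a number 5 percentage points lower from compound 3 to compound 4 (within the scatter) and in place of phenyl gives a number 1 percentage points lower from compound 1 to compound 4 (within the scatter), so this exchange adds no step beyond the scatter against either group. For the compounds shown here, what is new is a number 12 percentage points lower from compound 2 to compound 4 (beyond the scatter), the first step beyond the scatter that sets 3-methylphenyl apart from a group other than phenyl at this position. Compound 2 now differs beyond the scatter from compound 1 and compound 4, but compound 3 goes against any clean separation, since it stays within the scatter of all three. Nothing available here bears on the reason for these steps.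

As far as these compounds go, with so few groups at this position, it stays open whether the methyl group of compound 2 is what matters or whether other groups on the phenyl ring would do the same, such as an ethyl, a dimethylamino group or a carboxylic acid. Readings at one concentration also leave the potency of all four compounds open.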